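A Phenyl for a Methyl on the Imide Nitrogen

The compounds below may be only part of what the source reports. "The series", "measured", "known", "first", "only" and "open" are said of these compounds alone.

The series rests on a shared fused core, shown first as compound 1 `CC(C)[C@@H]1CC[C@@H](C)C[C@@]12N(C)C(=O)[C@@H]1[C@H]3C(=O)NC(=O)[C@H]3ON12`, for which the result in a functional assay, read by spectrophotometry, with a stated time of 2 h (a higher number here means a weaker inhibitor, a lower number a stronger inhibitor), is given as "not determined" (no result reported). Compound 2 `CC(C)[C@@H]1CC[C@@H](C)C[C@@]12N(C)C(=O)[C@@H]1[C@H]3C(=O)N(C)C(=O)[C@H]3ON12` carries a methyl on the amide-type nitrogen in the five-membered ring of that core, and in this assay compound 2 gives 2160 ug/mL. Among the measured compounds shown here, this is the only number available in the set, so compound 2 stands alone as the sole reference point, with no second measured compound to rank it against.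

Compound 3 `CC(C)[C@@H]1CC[C@@H](C)C[C@@]12N(C)C(=O)[C@@H]1[C@H]3C(=O)N(c4ccccc4)C(=O)[C@H]3ON12` differs from compound 2 in one place: phenyl in place of methyl on an amide-type nitrogen in a ring. For the measured compounds named here, no measured pair in this set shows what such a change does in this assay, so the direction of the step can only be guessed. The author's expectation is a step of a 1.4-fold lower number from compound 2 to compound 3 (0.16 log units; within the scatter), a shift that may well lie within the usual scatter of repeated measurements rather than beyond it. On that basis, compound 3 is estimated to give 1500 ug/mL in this assay, with a plausible range from 400 ug/mL to 5000 ug/mL.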

Compound 3, half-maximal inhibitory concentration: 2310 ug/mL
Estimate against measurement, compound 3: 1.5-fold (0.19 log units) below, within the range that was stated.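

In this assay, phenyl in place of methyl on the amide-type nitrogen in a ring comes with a 1.1-fold higher number from compound 2 to compound 3 (0.03 log units; within the scatter), so this read-out does not separate the two compounds. Among the compounds shown here, this is the first measured pair at this position, and it shows that a six-membered aromatic ring of carbon only can take the place of methyl here with the number staying within the scatter. Nothing available bears on why the two compounds read alike, so the result stands without an explanation.

From the compounds shown here alone, whether the amide hydrogen itself would read differently from methyl or phenyl stays open, since compound 1 is recorded as "not determined" (no result reported). Going by these compounds, it is also open whether this insensitivity holds for other groups on the same nitrogen, such as a longer chain like butyl, a benzyl group, or a phenyl ring carrying an amine or a carboxylic acid, and a single pair cannot show whether any such group would move the number beyond the scatter.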